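The source may report more compounds than this note shows. Statements on the series, on what has been measured and on what is new or still open speak of the compounds shown alone.

Measured so far in a functional assay on HEL cells (Homo sapiens) for cytotoxicity; on this read-out higher numbers stand for lower toxicity in this test and lower numbers for higher toxicity in this test:

compound 1, `CO[C@@H]1[C@@H](OC)[C@H](c2ccccc2)O[C@@H]2CO[C@@H](C3CCCCC3)O[C@@H]12`: 28 ug/mL
compound 2, `CO[C@@H]1[C@@H](OC)[C@H](c2ccccc2)O[C@@H]2CO[C@@H](Cc3ccccc3)O[C@@H]12`: "not determined" (no result reported)

Compound 1 carries a cyclohexyl group at the acetal carbon of the shared core and in this assay compound 1 gives 28 ug/mL. Compound 2 shares that core but carries a benzyl group at the same carbon; in this assay compound 2 is recorded as "not determined" (no result reported), so where compound 2 stands cannot be placed against compound 1 or anything else. Compound 3 is `CO[C@@H]1[C@@H](OC)[C@H](c2ccccc2)O[C@@H]2CO[C@@H](c3ccc(C(F)(F)F)cc3)O[C@@H]12`. The change from compound 2 to compound 3 is 4-(trifluoromethyl)phenyl in place of benzyl on a saturated ring carbon. Among the compounds with values here, no measured pair in the set shows a step of this kind, and with compound 2 itself unmeasured there is no anchor for the direction of the step; the only number in the set is that of compound 1, which sits in a moderate range for a test of this type. Compound 3 is therefore expected to land near the value of compound 1, with wide uncertainty in either direction, at roughly 25 ug/mL (range 8 ug/mL to 100 ug/mL), the estimate resting on compound 1 at 28 ug/mL alone.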

Compound 3, half-maximal cytotoxic concentration: > 50 ug/mL
Compound 3 gave a limit, no number (the forecaster's own chance of this, stated with the estimate: 30%); middle value at least 2.0-fold (0.30 log units) away from the limit.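

In this assay compound 3 gives > 50 ug/mL, which is a limit of the assay and not a number. At this saturated ring carbon between two ring oxygen atoms, 4-(trifluoromethyl)phenyl in place of cyclohexyl gives an at least 1.7-fold higher number from compound 1 to compound 3 (0.25 log units; that floor lies within the scatter), so this change brings no lower number in this test, while a rise beyond the scatter is not shown. Only a floor can be read for this step, the entry for compound 3 being a limit: the limit of > 50 ug/mL in this assay, at which 1 of the 3 values shown sits.

The step from compound 2 to compound 3 cannot be read, so the benzyl group has no place in the order of this series. Open too, going by these compounds, are how far compound 3 lies from its limit and whether the read-out at this carbon stays the same with a plain phenyl group, or with an amine or a carboxylic acid on the aromatic ring in place of trifluoromethyl.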